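Trifluoromethyl for Methyl on a Bile Acid Receptor Antagonist

The compounds below may be only part of what the source reports. "The series", "measured", "known", "first", "only" and "open" are said of these compounds alone.

Compound 1 `Cc1ccc(-c2nn(C(C)C)cc2C(=O)Nc2ccc(C)c(S(=O)(=O)N3CCOCC3)c2)cc1` stands highest of the two measured compounds in an assay on isolated protein for antagonist activity at Bile acid receptor (Homo sapiens), read by TR-FRET, with a stated time of 20 min, tested at 4.4 uM (a lower number here means less inhibition, a higher number more inhibition at the concentration tested (going by the name of the read-out)), where compound 1 gives 131%. The nearest measured compound is compound 2 `COc1cccc(Cn2cc(C(=O)Nc3ccc(C)c(S(=O)(=O)N4CCOCC4)c3)c(C(C)C)n2)c1`, which in this assay gives 101%, a gap beyond the usual scatter. Compound 3 `Cc1ccc(NC(=O)c2cn(C(C)C)nc2-c2ccc(C(F)(F)F)cc2)cc1S(=O)(=O)N1CCOCC1` differs from compound 1 by a single change: trifluoromethyl in place of methyl on an aromatic carbon. Among the measured compounds shown here, no pair of measured compounds shows the effect of this change, so the step remains uncertain. The expected step of a number 9 percentage points lower from compound 1 to compound 3 (within the scatter) lies within the scatter. The estimate for compound 3 in this assay is 122%, expected between 90% and 145%.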

Compound 3, a percentage reported as inhibition, at one concentration (the size of the read-out at that concentration, not a potency): 133%
For compound 3 the middle estimate is 11 percentage points below the measured one; low and high end bracket the measured number.
By their numbers in this assay, from the lowest: compound 2; then compounds 1 and 3 (each within the scatter of the next).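

Trifluoromethyl in place of methyl on this aromatic carbon gives the first measured step at this position: in this assay, the read-out moves by a number 2 percentage points higher from compound 1 to compound 3 (within the scatter). The 4-methylphenyl and 4-(trifluoromethyl)phenyl groups therefore cannot be told apart in this assay, and the position takes either group without losing inhibition at the concentration tested. No measurement here offers an explanation for this result. On these data alone, whether an amine, a carboxylic acid or a longer chain at this position would keep the inhibition stays open. Also open, as far as these compounds go, is how compound 1 and compound 3 compare in potency, as a single concentration does not give one.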